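The source may hold more compounds than are shown below. What is called first, only, known or untested is meant among the compounds shown, and "the series" means these compounds.

Of the compounds shown here, three built on one shared core have been measured in a functional assay on the whole organism with Cavia porcellus as the target; on this read-out lower numbers stand for an effect already at smaller amounts and higher numbers for an effect only at larger amounts of compound. Compound 1 `c1ccc2nc(COc3ccc(CC4CCCC4Cc4nnn[nH]4)cc3)ccc2c1` gives 12 mg/kg, compound 3 `c1ccc2nc(COc3ccc(CCC4(Cc5nnn[nH]5)CCCC4)cc3)ccc2c1` gives 2.8 mg/kg, and compound 2 `CC(CCc1nnn[nH]1)Cc1ccc(OCc2ccc3ccccc3n2)cc1` gives 1.2 mg/kg, the lowest of the three numbers. Compound 3 stands nearest to compound 2 and compound 1 furthest, and both gaps lie beyond the usual scatter. Compound 4 `CCCC(CCC(=O)O)Cc1ccc(OCc2ccc3ccccc3n2)cc1` has not yet been measured. It differs from compound 2 in a single place: 1-(2-carboxyethyl)butyl in place of 3-(1H-tetrazol-5-yl)-1-methylpropyl on a saturated chain carbon bound to an aromatic carbon. Within the data shown here, no pair among the measured compounds shows the effect of such a swap, so the guidance is thin. A modest shift toward a higher number is expected, and for compound 4 the expected step is a 2.1-fold higher number from compound 2 to compound 4 (0.32 log units; beyond the scatter). In this assay compound 4 is estimated at 2.5 mg/kg, with a range from 0.8 mg/kg to 8 mg/kg.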

Compound 4, dose for half-maximal effect: 9.7 mg/kg
Compound 4: middle estimate off by 3.9-fold (0.59 log units), on the low side; the measured number lies above the stated range.
By their numbers in this assay, from the lowest: compound 2; then compound 3; then compounds 4 and 1 (each within the scatter of the next).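

In this assay, among these compounds, putting 1-(2-carboxyethyl)butyl in place of 3-(1H-tetrazol-5-yl)-1-methylpropyl on a saturated chain carbon bound to an aromatic carbon gives an 8.1-fold higher number from compound 2 to compound 4 (0.91 log units; beyond the scatter) and is the first step read at this position. Both groups count the same heavy atoms and hydrogen-bond donors, so matching those counts does not keep the number unchanged. Nothing available explains the step.

Going by these compounds, the swap changes the acidic end group's ring and the chain together, so the share of each stays open. On these data alone, an amide at the chain end, or an ethyl branch, also remains open.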